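The source may report more compounds than this note shows. Statements on the series, on what has been measured and on what is new or still open speak of the compounds shown alone.

Two amides have been read so far in an ADME assay on L6 cells (Rattus norvegicus) for cytotoxicity, read by resazurin assay, with a stated time of 72 h; on this read-out lower numbers stand for stronger inhibition and higher numbers for weaker inhibition. Compound 1 `O=C(NCCCCn1cnc([N+](=O)[O-])n1)c1ccsc1` gives > 339000 nM, which is a limit of the assay and not a number. Compound 2 `Cc1cc(C(=O)NCCCn2cnc([N+](=O)[O-])n2)c(C)o1` gives > 341000 nM, and this too is a limit. Compound 2 therefore has no numerical position in the series, and the only other result available is also a limit. Among the measured compounds shown here, no step between measured compounds can be read from these data.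

Compound 3 `O=C(NCCCn1cnc([N+](=O)[O-])n1)c1ccnc(Cl)c1` follows from compound 2 by placing 2-chloropyridin-4-yl in place of 2,5-dimethylfuran-3-yl on a carbonyl carbon. Compound 2 at > 341000 nM offers only a limit as a starting point, so no change beyond the scatter is expected in this assay. The expected step is an at least 1.2-fold lower number from compound 2 to compound 3 (0.08 log units; that floor lies within the scatter). For compound 3 the estimated value is 280000 nM, with an expected range of 100000 nM to 400000 nM.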

Compound 3, half-maximal inhibitory concentration: > 322000 nM
Compound 3 ended at the assay's limit; the forecaster's own chance of this, stated with the estimate: 65%; middle value at least 1.1-fold (0.06 log units) away from the limit.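

Compound 3 reads > 322000 nM, a limit of the assay and not a number. Compound 2 also stands at a limit, so the step between compound 2 and compound 3 cannot be read. The compounds shown leave open whether 2-chloropyridin-4-yl in place of 2,5-dimethylfuran-3-yl changes the read-out in this assay at all.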